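Changing the ring on the amide nitrogen: compound 3

The source may hold more compounds than are shown below. What is called first, only, known or untested is meant among the compounds shown, and "the series" means these compounds.

- Compound 1 (`Cc1cnc(NC(=O)CSc2nncnc2-c2ccccc2Cl)c(Br)c1`) gives 144000 nM
- Compound 2 (`Cc1ccc(NC(=O)CSc2nncnc2-c2ccccc2Cl)c(Br)c1`) gives 45000 nM

In an ADME assay on MT4 cells (Homo sapiens) for cytotoxicity, read by MTT assay (a lower number here means that less compound is tolerated, a higher number that more compound is tolerated), compound 2 has the lower of the two numbers. Compound 3 (`O=C(CSc1nncnc1-c1ccccc1Cl)Nc1ccc(Cl)cc1Cl`) carries 2,4-dichlorophenyl in place of 2-bromo-4-methylphenyl on the amide-type nitrogen (2,4-dichlorophenyl in place of 2-bromo-4-methylphenyl on an amide-type nitrogen). Among the compounds with values here, the only measured step (a 3.2-fold lower number from compound 1 to compound 2 (0.51 log units; beyond the scatter)) was modest and replaced a different ring, 3-bromo-5-methylpyridin-2-yl, so it bears only loosely on this swap of one ring of carbon only for another. No step beyond the scatter is therefore expected in this assay in either direction. The expected step (a 1.1-fold lower number from compound 2 to compound 3 (0.05 log units; within the scatter)) stays small. Compound 3 is estimated at 40000 nM (expected range 15000 nM to 110000 nM).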

Compound 3, half-maximal cytotoxic concentration: 51000 nM
Beside the measured number, compound 3's estimate is 1.3-fold (0.11 log units) below it; the measured number falls inside the stated range.
By their numbers in this assay, from the lowest: compounds 2 and 3 (each within the scatter of the next); then compound 1.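

In this assay there is a 1.1-fold higher number from compound 2 to compound 3 (0.05 log units; within the scatter) and so 2,4-dichlorophenyl and 2-bromo-4-methylphenyl on the amide-type nitrogen cannot be told apart. Set against 3-bromo-5-methylpyridin-2-yl, there is also a 2.8-fold lower number from compound 1 to compound 3 (0.45 log units; beyond the scatter) so two different rings of carbon only now both give lower numbers than compound 1. No measurement at hand explains this difference.

The compounds shown leave open what an amine or a carboxylic acid on the ring would do to the number. A longer chain in place of the ring on this nitrogen also remains an open case.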